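This account rests on a few compounds, and the source may have more. Where it says the series, first, only, none or still open, it means among the compounds named here.

Compound 1 `O=c1cc(Cn2cc(CNS(=O)(=O)c3ccc(F)cc3)nn2)c2ccc(O)cc2o1` — > 100000 nM
Compound 2 `Cn1c(-c2cn(Cc3cc(=O)oc4cc(O)ccc34)nn2)nc2ccccc21` — > 100000 nM

In a functional assay on SW-620 cells (Homo sapiens) for inhibition, read by MTT assay, with a stated time of 72 h (on this read-out higher numbers stand for weaker inhibition and lower numbers for stronger inhibition), compound 1 reaches only the limit of the assay, > 100000 nM. In this assay compound 2 likewise gives only a limit, > 100000 nM. Compound 2 therefore sits on (the limit of > 100000 nM in this assay, at which 2 of the 2 values shown sit), with no numerical value of its own to build on. Compound 3 `Cc1ccc2c(Cn3cc(-c4nc5ccccc5n4C)nn3)cc(=O)oc2c1` differs from compound 2 by methyl in place of hydroxy on an aromatic carbon. For the measured compounds named here, with no measured step to lean on, no change beyond the scatter is expected in this assay, and compound 3 is expected to stay at the limit as well. The step from compound 2 to compound 3 is expected to be a number no higher from compound 2 to compound 3 (the limit leaves the size open). For compound 3 the estimate is 100000 nM, ranging from 30000 nM to 300000 nM.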

Compound 3, half-maximal inhibitory concentration: > 100000 nM
Compound 3 was reported as a limit; the forecaster's own chance of this, stated with the estimate: 75%; the middle value sits exactly at the limit.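

For the compounds shown here, compound 2 and compound 3 both stay at the limit of this assay, so no step between them can be read. The compounds shown leave open whether methyl in place of hydroxy changes inhibition at all, since none gives a number: the limit of > 100000 nM in this assay, at which 3 of the 3 values shown sit.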